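From 2-fluorobenzyl to 2-chlorobenzyl on a shared core

The compounds below may be only part of what the source reports. "The series", "measured", "known", "first", "only" and "open" are said of these compounds alone.

Of the compounds shown here, two on the shared core have been read so far in a functional assay on MCF7 cells (Homo sapiens) for cytotoxicity, read by MTT assay, with a stated time of 24 h; a higher number here means a weaker inhibitor, a lower number a stronger inhibitor. Compound 1 `Cc1ccc(/C=C2\CN(Cc3cn(Cc4cccc(Cl)c4)nn3)C/C(=C\c3ccc(C)cc3)C2=O)cc1`, carrying a 3-chlorophenyl group, gives 10000 nM. Compound 2 `Cc1ccc(/C=C2\CN(Cc3cn(Cc4ccccc4F)nn3)C/C(=C\c3ccc(C)cc3)C2=O)cc1`, carrying a 2-fluorophenyl group, gives 28700 nM, the higher of the two numbers. Among the measured compounds shown here, the only measured step is a 2.9-fold higher number from compound 1 to compound 2 (0.46 log units; beyond the scatter), and it is modest in size.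

Compound 3 `Cc1ccc(/C=C2\CN(Cc3cn(Cc4ccccc4Cl)nn3)C/C(=C\c3ccc(C)cc3)C2=O)cc1` keeps the core and replaces 2-fluorophenyl with 2-chlorophenyl: chloro in place of fluoro on an aromatic carbon. This is chloro in place of fluoro on an aromatic carbon, ortho to a large group. The measured step bears on this change only in part, since it alters the halogen and its place together, and the data do not separate the two. For the measured compounds named here, still, the one chloro compound read so far, compound 1, stands at the lower number of 10000 nM. A modest move to a lower number is therefore expected: a 2.2-fold lower number from compound 2 to compound 3 (0.34 log units; beyond the scatter). For compound 3 the estimated value is 13000 nM, with an expected range of 5000 nM to 35000 nM.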

Compound 3, half-maximal inhibitory concentration: 66700 nM
The estimate for compound 3 lay 5.1-fold (0.71 log units) below the measured number; the measured number lies above the stated range.
By their numbers in this assay, from the lowest: compound 1; then compound 2; then compound 3.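

In this assay, chloro in place of fluoro on an aromatic carbon, ortho to a large group, does not move the series toward the lower number of compound 1: the swap gives a 2.3-fold higher number from compound 2 to compound 3 (0.37 log units; beyond the scatter), so having chloro on the ring does not by itself place a compound at the low end of this set. With the halogen held as chloro, 2-chlorophenyl in place of 3-chlorophenyl gives a 6.7-fold higher number from compound 1 to compound 3 (0.82 log units; beyond the scatter), the largest step among the three compounds and one beyond the scatter, which shows that where the chloro sits counts on this core as well as which halogen is present. No measurement at hand accounts for either step.

The compounds shown leave open how a plain phenyl group, with no halogen at all, would rank against these three, and so whether either halogen at this place raises the number or only chloro does. They also leave open whether a methoxy group, an amine or a carboxylic acid on the same aromatic carbon would continue the order seen with fluoro and chloro.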